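Chloro for Methoxy on a Second Curcuminoid Core

The compounds below may be only part of what the source reports. "The series", "measured", "known", "first", "only" and "open" are said of these compounds alone.

The measured compounds:
compound 1, `COc1ccc2c(c1)nc(/C=C/C(=O)/C=C/c1ccc(O)c(OC)c1)n2C`, 3800 nM
compound 2, `COc1cc(/C=C/C(=O)/C=C/c2nc3cc(Cl)ccc3n2C)ccc1O`, 4000 nM
compound 3, `COc1ccc2c(c1)nc(/C=C/C(=O)/C=C/c1ccc(OC)c(O)c1)n2C`, 4200 nM

Of the compounds shown here, three have been tested in a functional assay on HepG2 cells (Homo sapiens) for cytotoxicity, read by MTT assay, with a stated time of 48 h (a higher number here means a weaker inhibitor, a lower number a stronger inhibitor), and their numbers sit close together. In this assay compound 1 gives 3800 nM, compound 2 gives 4000 nM and compound 3 gives 4200 nM. Compound 2 differs from compound 1 by chloro in place of methoxy on an aromatic carbon, and this step gave a 1.1-fold higher number from compound 1 to compound 2 (0.02 log units; within the scatter). Compound 3 differs from compound 1 by 3-hydroxy-4-methoxyphenyl in place of 4-hydroxy-3-methoxyphenyl on a double-bonded chain carbon bound to a double-bonded chain carbon, and that step gave a 1.1-fold higher number from compound 1 to compound 3 (0.04 log units; within the scatter). Neither change moved the number by more than the scatter of this assay.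

Compound 4, `COc1ccc(/C=C/C(=O)/C=C/c2nc3cc(Cl)ccc3n2C)cc1O`, has not yet been measured. It differs from compound 3 by chloro in place of methoxy on an aromatic carbon, the same change that was made from compound 1 to compound 2, occurring twice among these compounds. Because a 1.1-fold higher number from compound 1 to compound 2 (0.02 log units; within the scatter) stayed within the scatter on the core of compound 1, the same change on the core of compound 3 is expected to give a step of a 1.0-fold higher number from compound 3 to compound 4 (0.02 log units; within the scatter), again within the scatter. This rests on a single earlier instance and on the closeness of all three measured values. Compound 4 is therefore expected to give about 4400 nM in this assay. The estimate for compound 4 is expected to lie between 2200 nM and 8800 nM.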

Compound 4, half-maximal inhibitory concentration: 4100 nM
For compound 4 the middle estimate is 1.1-fold (0.03 log units) above the measured one; measured number inside the range.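

In this assay, chloro in place of methoxy on an aromatic carbon gave a 1.0-fold lower number from compound 3 to compound 4 (0.01 log units; within the scatter) on the core of compound 3, a step as small as the one seen earlier on the core of compound 1. Within the data shown here, this shows only that the change can be carried between these two closely related cores, which differ in the placing of the hydroxy and methoxy groups on the phenyl ring, without a step that can be told from the scatter; it does not show that the same would hold on a more distant core, or in any other measurement, and steps this small cannot reveal a slight dependence on the core. Set side by side, the two instances do not differ, so within this small series the change behaves alike on both cores: the same change on two cores in this assay, a 1.1-fold higher number (0.02 log units; within the scatter) from compound 1 to compound 2 and a 1.0-fold lower number (0.01 log units; within the scatter) from compound 3 to compound 4, 1.1-fold (0.03 log units) apart, within the scatter of two such steps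

The compounds shown leave open whether another group on that aromatic carbon, such as an amine, a carboxylic acid or a longer alkoxy chain, would move the number beyond the scatter. They also leave open whether the phenyl end of the molecule would tolerate an amine in place of its hydroxy group as readily as it tolerates the exchange of hydroxy and methoxy seen here.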